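Halogen swap on the fused ring of the shared core

A few compounds are considered here, and "the series" means these few. Any claim that something is new, unique, unknown or untested is made for them only; others in the source may bear on it.

Measured compounds:
compound 1 `COc1ccc(C2=NN(C3=NC(=O)/C(=C4\C(=O)Nc5ccc(Cl)cc54)S3)C(c3ccc(OC)cc3)C2)cc1` — 390 nM
compound 2 `COc1ccc(C2=NN(C3=NC(=O)/C(=C4\C(=O)Nc5ccccc54)S3)C(c3ccc(Cl)cc3)C2)cc1` — 100000 nM
compound 3 `COc1ccc(C2=NN(C3=NC(=O)/C(=C4\C(=O)Nc5ccc(Br)cc54)S3)C(c3ccc(Cl)cc3)C2)cc1` — 370 nM

In a functional assay on cells (Cancer cell lines, Homo sapiens) for cytotoxicity, read by sulforhodamine B assay, with a stated time of 48 h (a lower number here means a stronger inhibitor of growth, a higher number a weaker inhibitor of growth), compound 3 gives 370 nM, the lowest of the three numbers. Compound 1 lies within the scatter of it, so no order between compound 3 and compound 1 can be read from these two values. Compound 2 stands far higher, at 100000 nM.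

The next compound is compound 4 `COc1ccc(C2=NN(C3=NC(=O)/C(=C4\C(=O)Nc5ccc(Cl)cc54)S3)C(c3ccc(Cl)cc3)C2)cc1`, obtained through the change (chloro in place of bromo on an aromatic carbon). Going by the values given here, the one measured step that bears on this position is a 270-fold lower number from compound 2 to compound 3 (2.43 log units; beyond the scatter), a large drop on putting a halogen onto a previously unsubstituted carbon. Compound 4 keeps a halogen there, so that step argues against a return toward compound 2. Among the compounds with values here, compound 1 carries chloro at the same position and differs from compound 3 in two places, so no single step is available for it. The value of compound 1, 390 nM, only shows that chloro at this site sits with a number close to that of compound 3.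

The expectation is therefore a step of a 1.1-fold higher number from compound 3 to compound 4 (0.03 log units; within the scatter) in this assay, within the scatter in either direction. Compound 4 is estimated at 400 nM, with a range from 150 nM to 1100 nM.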

Compound 4, concentration for total growth inhibition: 460 nM
Compound 4: middle estimate off by 1.2-fold (0.06 log units), on the low side; measured number inside the range.
By their numbers in this assay, from the lowest: compounds 3, 1 and 4 (each within the scatter of the next); then compound 2.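

Notes on the halogen site: in this assay, bromo and chloro on this aromatic carbon cannot be told apart, with a 1.2-fold higher number from compound 3 to compound 4 (0.09 log units; within the scatter) as the step between them. Chloro in place of hydrogen at the same carbon gives a 220-fold lower number from compound 2 to compound 4 (2.34 log units; beyond the scatter) and stands alongside a 270-fold lower number from compound 2 to compound 3 (2.43 log units; beyond the scatter) for bromo, so the large drop from the unsubstituted compound is now seen with two halogens rather than with bromo alone. The other varied site now has a single-change comparison, and chloro in place of methoxy there gives a 1.2-fold higher number from compound 1 to compound 4 (0.07 log units; within the scatter) with no readable difference in this assay between these two groups.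

No measurement here bears on why the halogen-bearing compounds and the unsubstituted compound lie so far apart.

Going by these compounds, it remains open whether the low numbers need a halogen at all, since a methyl group, an amine or a carboxylic acid on this aromatic carbon would test whether other groups also stand far from compound 2. On these data alone, it also remains open whether methoxy and chloro at the other site stay level when bromo, or hydrogen, occupies the halogen site.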